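The compounds below may be only part of what the source reports. "The series", "measured", "known", "first", "only" and "open" are said of these compounds alone.

Within the data shown here, in a functional assay on MCF7 cells (Homo sapiens) for antiproliferative activity, read by MTT assay, with a stated time of 48 h (on this read-out higher numbers stand for weaker inhibition and lower numbers for stronger inhibition), compound 1 (`COc1ccc(C(=O)c2ccc(OC)c3c2OC(C)(C)C=C3)c(NC(=O)CBr)c1`) gives 2360 nM, the lower of the two numbers measured so far. Compound 2 (`CCNCC(=O)Nc1cc(OC)ccc1C(=O)c1ccc2c(c1)C=CC(C)(C)O2`), which carries no bromo group, gives 6310 nM. Compound 3 (`COc1ccc(C(=O)c2ccc(OC)c3c2OC(C)(C)C=C3)c(NC(=O)CN(C)C)c1`) departs from compound 1 by one change, dimethylamino in place of bromo on a saturated chain carbon bound to a carbonyl carbon. Among the measured compounds shown here, no measured pair isolates this change, so the expectation leans only on the higher number of compound 2 at 6310 nM. A moderate step toward weaker inhibition in this assay is expected, with the estimated step of a 2.1-fold higher number from compound 1 to compound 3 (0.33 log units; beyond the scatter). For compound 3 the estimate is 5000 nM, with an expected range of 2000 nM to 13000 nM.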

Compound 3, half-maximal inhibitory concentration: 2680 nM
For compound 3 the middle estimate is 1.9-fold (0.27 log units) above the measured one; the range from low to high includes it.
By their numbers in this assay, from the lowest: compounds 1 and 3 (each within the scatter of the next); then compound 2.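

In this assay, dimethylamino in place of bromo on a saturated chain carbon bound to a carbonyl carbon is a step of a 1.1-fold higher number from compound 1 to compound 3 (0.06 log units; within the scatter), so the two groups cannot be told apart at this place. On this core, then, the number does not hang on bromo, and three heavy atoms in its stead are taken up with no change beyond the scatter. No measured evidence says why the two groups read alike. From the compounds shown here alone, whether a primary amine, a carboxylic acid or a longer chain carrying the dimethylamino would read the same remains open.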